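The source may report more compounds than this note shows. Statements on the series, on what has been measured and on what is new or still open speak of the compounds shown alone.

Measured compounds:
Compound 1, `CCSc1nnc(Cc2ccccc2Oc2ccccc2)[nH]1`: 132%
Compound 2, `CCCSc1nnc(Cc2ccccc2Oc2ccccc2)[nH]1`: 128%
Compound 3, `CSc1nnc(Cc2ccc(Cl)cc2Oc2ccccc2F)[nH]1`: 110%

The three measured compounds were tested in a functional assay on the whole organism (strain NMRI) with Mus musculus as the target, with a stated time of 60 min, at a dose of 5 mg/kg by the intraperitoneal route; on this read-out higher numbers stand for a stronger effect at the one dose given and lower numbers for a weaker effect. Compound 1 gives 132% in this assay, and compound 2 gives 128%. The two differ by methyl in place of hydrogen on a saturated chain carbon, two bonds along the chain from a sulfur, and this change made a number 4 percentage points lower from compound 1 to compound 2 (within the scatter). Compound 3 gives 110% in this assay, the lowest of the three, beyond the scatter from both compound 1 and compound 2. How the core of compound 3 differs from the core of compound 1 is not broken down here.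

Compound 4, `CCSc1nnc(Cc2ccc(Cl)cc2Oc2ccccc2F)[nH]1`, has not yet been measured in this assay. It differs from compound 3 by methyl in place of hydrogen on a saturated chain carbon bound to a sulfur. This is the same kind of change as that from compound 1 to compound 2, but the place differs: there the methyl entered on a saturated chain carbon two bonds along the chain from a sulfur, here on a saturated chain carbon bound to a sulfur. Because the earlier step gave a number 4 percentage points lower from compound 1 to compound 2 (within the scatter), the step from compound 3 to compound 4 is expected to be small, no change at the digits printed from compound 3 to compound 4 (within the scatter). Compound 4 is thus estimated to give 110% in this assay, expected to fall between 92% and 128%.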

Compound 4, a percentage reported as activity, at one dose (the size of the read-out at that dose, not a potency): 126%
Estimate against measurement, compound 4: 16 percentage points below; the range from low to high includes it.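

In this assay, methyl in place of hydrogen on a saturated chain carbon does not act as one fixed step from core to core: the same change on two cores in this assay, a number 4 percentage points lower (within the scatter) from compound 1 to compound 2 and a number 16 percentage points higher (beyond the scatter) from compound 3 to compound 4, 20 percentage points apart, beyond the scatter of two such steps. On the core of compound 3, where methylsulfanyl becomes ethylsulfanyl, the change gave a number 16 percentage points higher from compound 3 to compound 4 (beyond the scatter), so a result read on the core of compound 1 did not predict the step on this core. Among the compounds shown here, this does not show that the core alone sets the size of the step, since the methyl enters at a different place on the chain in each pair, and with only one pair per core the two influences cannot be separated.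

The compounds shown leave open whether the step from methylsulfanyl to ethylsulfanyl would behave the same way on the core of compound 1, and whether a longer chain on the core of compound 4 would keep its value. Also open, as far as these compounds go, is how an amine or a carboxylic acid on the sulfur chain would read on either core.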